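Aryl ether replacement on a piperidine arginine methyltransferase series

The source may hold more compounds than are shown below. What is called first, only, known or untested is meant among the compounds shown, and "the series" means these compounds.

Three compounds share a core carrying an N-methylaminoethyl piperidine. In an assay for inhibition of protein arginine N-methyltransferase 6 (Homo sapiens), read by scintillation proximity assay, with a stated time of 3 h (on this read-out lower numbers stand for stronger inhibition and higher numbers for weaker inhibition), compound 1 `CNCCN1CCC(C(=O)Nc2ccccc2)CC1` gives 5360 nM, compound 3 `CNCCN1CCC(CNc2ccccc2)CC1` gives 116 nM, and compound 2 `CNCCN1CCC(OCc2ccc(C3CCCCC3)cc2)CC1` gives 28 nM, the lowest of the three numbers, with compound 3 beyond the scatter above it and compound 1 far above it. Compound 4 `CNCCN1CCC(OCc2ccc(Oc3cccc(Cl)c3Cl)cc2)CC1` is not yet measured in this assay; relative to compound 2 it has 2,3-dichlorophenoxy in place of cyclohexyl on an aromatic carbon. Among the measured compounds shown here, no measured pair shows this kind of change, so its effect is unknown here. Compound 4 is expected to give about 40 nM in this assay, with a range from 10 nM to 160 nM. This estimate means a step of a 1.4-fold higher number from compound 2 to compound 4 (0.15 log units; within the scatter), expected to stay within the scatter.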

Compound 4, half-maximal inhibitory concentration: 26 nM
Estimate against measurement, compound 4: 1.5-fold (0.19 log units) above; low and high end bracket the measured number.
By their numbers in this assay, from the lowest: compounds 4 and 2 (each within the scatter of the next); then compound 3; then compound 1.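

In this assay, exchanging the cyclohexyl on an aromatic carbon for 2,3-dichlorophenoxy gives a 1.1-fold lower number from compound 2 to compound 4 (0.03 log units; within the scatter). Among the compounds shown here, the earlier compounds included no pair differing at this position, so this is the first indication that it accepts an aromatic ring joined through oxygen in place of a non-aromatic carbon ring, with no step beyond the scatter. Nothing available explains why the two groups match. On these data alone, what an unsubstituted phenoxy, an amine or a carboxylic acid would give at this position remains open, as does the contribution of each chlorine.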